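The source may hold more compounds than are shown below. What is called first, only, known or untested is meant among the compounds shown, and "the series" means these compounds.

Working notes on the cyclopropylidene series in an ADME assay on Akata cells (Homo sapiens) for cytotoxicity, with a stated time of 7 days; on this read-out higher numbers stand for lower toxicity in this test and lower numbers for higher toxicity in this test.

Compound 1 `Nc1nc(NCc2ccccc2)c2ncn(/C=C3/CC3(CO)CO)c2n1` is the reference point. In this assay compound 1 gives > 24000 nM, which is a limit of the assay and not a measured number. Compound 2 `CCCCNc1nc(N)nc2c1ncn2/C=C1/CC1(CO)CO` likewise gives > 24000 nM in this assay, again a limit. Compound 3 `Nc1nc2c(ncn2/C=C2/CC2(CO)CO)c(=O)[nH]1` gives > 20000 nM in this assay, also a limit. Compound 1 thus stands at the same assay ceiling as the other two compounds, with nothing ranking them; two values sit at the limit of > 24000 nM in this assay, at which 2 of the 3 values shown sit, and one at the limit of > 20000 nM in this assay, at which 1 of the 3 values shown sits.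

Among the compounds with values here, the only step between measured compounds is a step that the two limits leave unreadable from compound 1 to compound 2, and with both ends at limits it has no readable size.

Compound 4 `CCCCCCCCSc1nc(N)nc2c1ncn2/C=C1/CC1(CO)CO` carries the change (octylsulfanyl in place of benzylamino on an aromatic carbon). Within the data shown here, no measured step covers this exchange; the step from compound 1 to compound 2 bears on it only in that a different chain on the same position left the value at its limit. The expected outcome is therefore another value at or near the assay ceiling, with an at least 1.2-fold lower number from compound 1 to compound 4 (0.07 log units; that floor lies within the scatter) expected to show no change beyond the scatter. Compound 4 is estimated at 20000 nM, within 7000 nM to 50000 nM.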

Compound 4, half-maximal cytotoxic concentration: > 20000 nM
Compound 4 gave a limit, no number; the forecaster's own chance of this, stated with the estimate: 60%; the middle value lies on the limit itself.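

Compound 4 gives > 20000 nM in this assay, which is a limit and not a number. Its steps from compound 1 and compound 2 cannot be read. The compounds shown leave open how octylsulfanyl, benzylamino and butylamino rank on the aromatic carbon.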